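This account rests on a few compounds, and the source may have more. Where it says the series, first, only, none or still open, it means among the compounds named here.

In a functional assay on A549 cells (Homo sapiens) for antiproliferative activity, read by MTT assay, with a stated time of 48 h (on this read-out higher numbers stand for weaker inhibition and lower numbers for stronger inhibition), three compounds have been measured. Compound 1 `O=[N+]([O-])c1cc(C(F)(F)F)cc([N+](=O)[O-])c1Oc1ccccc1/C=N\OCc1ccccc1F` gives 860 nM, compound 2 `O=[N+]([O-])c1cc(C(F)(F)F)cc([N+](=O)[O-])c1Oc1ccc(Cl)cc1/C=N\OCc1ccccc1` gives 3410 nM, and compound 3 `O=[N+]([O-])c1cc(C(F)(F)F)cc([N+](=O)[O-])c1Oc1c(Cl)cc(Cl)cc1/C=N\OCc1ccccc1` gives 1450 nM. Compound 3 therefore lies within the scatter of compound 1 and clearly below compound 2.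

Compound 4 `O=[N+]([O-])c1cc(C(F)(F)F)cc([N+](=O)[O-])c1Oc1c(Cl)cc(Cl)cc1/C=N/OCc1ccccc1Cl` keeps most of compound 3 but exchanges one group: a group of 11 heavy atoms (8 carbon, 1 nitrogen, 1 oxygen, 1 chlorine; one six-membered aromatic ring of carbon only) in place of a group of 10 heavy atoms (8 carbon, 1 nitrogen, 1 oxygen; one six-membered aromatic ring of carbon only), on an aromatic carbon. The group that enters holds one chlorine more than the group that leaves.

Among the compounds with values here, only one measured step offers a guide. Chloro in place of hydrogen on an aromatic carbon gave a 2.4-fold lower number from compound 2 to compound 3 (0.37 log units; beyond the scatter), a modest change beyond the scatter. Within the data shown here, that chloro went onto a different part of the molecule, so it is only a loose precedent, and no measured step shows this exact exchange.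

A small move toward a lower number in this assay is expected, possibly no larger than the scatter. The expected change is a 1.5-fold lower number from compound 3 to compound 4 (0.16 log units; within the scatter). Compound 4 is estimated at 1000 nM, with an expected range of 350 nM to 3000 nM.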

Compound 4, half-maximal inhibitory concentration: 2160 nM
Compound 4: middle estimate off by 2.2-fold (0.33 log units), on the low side; the measured number falls inside the stated range.
By their numbers in this assay, from the lowest: compounds 1, 3, 4 and 2 (each within the scatter of the next, the first and the last beyond it).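

In this assay the group carrying one more chlorine gives a 1.5-fold higher number from compound 3 to compound 4 (0.17 log units; within the scatter) and this step lies within the scatter, so adding this chlorine produces no change that can be told apart from repeat-measurement noise. The earlier chloro step, made elsewhere on the molecule, gives a 2.4-fold lower number from compound 2 to compound 3 (0.37 log units; beyond the scatter) and lies beyond the scatter, so these compounds show that a chloro does not have the same outcome in both places. No measurement here explains this difference.

On these data alone, whether a different group at this carbon, such as a methoxy or a nitrile, would move the number beyond the scatter remains open. Compound 3 and compound 4 are also drawn with opposite geometry at the carbon-nitrogen double bond, so the contributions of the chlorine and of that geometry cannot be separated.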